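This account rests on a few compounds, and the source may have more. Where it says the series, first, only, none or still open, it means among the compounds named here.

Measured compounds in a functional assay on HepG2 cells (Homo sapiens) for cytotoxicity, read by MTT assay, with a stated time of 48 h; on this read-out lower numbers stand for stronger inhibition and higher numbers for weaker inhibition:

Compound 1 `COc1cc(-c2nnc(SCc3ccccc3Cl)n2N2C(=O)c3ccccc3C2=O)cc(OC)c1OC`, for which this assay gives > 200000 nM, a limit of the assay rather than a number.
Compound 2 `COc1cc(-c2nnc(SCc3ccccc3)n2N2C(=O)c3ccccc3C2=O)cc(OC)c1OC`, for which this assay gives > 200000 nM, again a limit of the assay and not a number.

Compound 2 therefore stands only at a limit in this assay; the other value shown is likewise a limit, so neither compound can be placed above or below the other. Within the data shown here, the one step between measured compounds, hydrogen in place of chloro on an aromatic carbon, reads a step that the two limits leave unreadable from compound 1 to compound 2 and gives no size. Among the measured compounds shown here, the only evidence on the measured values is the limit of > 200000 nM in this assay, at which 2 of the 2 values shown sit.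

Compound 3 `COc1cc(-c2nnc(SCC(=O)c3ccccc3)n2N2C(=O)c3ccccc3C2=O)cc(OC)c1OC` differs from compound 2 by benzoyl in place of phenyl on a saturated chain carbon bound to a sulfur, that is, benzyl to benzoylmethyl, benzylsulfanyl to (benzoylmethyl)sulfanyl. No measured step bears on a benzoyl group, and the one step shown is unreadable, so no direction can be expected beyond the scatter. For compound 3 the expected step in this assay is a step that the limit leaves unreadable from compound 2 to compound 3. Compound 3 is therefore estimated at 250000 nM, in a range from 50000 nM to 1000000 nM, most likely reported as a limit.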

Compound 3, half-maximal inhibitory concentration: 171000 nM
For compound 3 the middle estimate is 1.5-fold (0.16 log units) above the measured one; the measured number falls inside the stated range.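

In this assay, among these compounds, benzoyl in place of phenyl on a saturated chain carbon bound to a sulfur gives the only number among the three compounds rather than a limit, with compound 3 at 171000 nM. This change reads as an at least 1.1-fold lower number from compound 2 to compound 3 (0.06 log units; that floor lies within the scatter), and benzoyl in place of 2-chlorophenyl at that place reads as an at least 1.1-fold lower number from compound 1 to compound 3 (0.06 log units; that floor lies within the scatter), so each step is known only by a floor, and neither floor separates the compounds beyond the scatter. On these data alone, the step that replaces chloro with hydrogen cannot be read, and the true size of both new steps stays unknown, since the other two values are limits of the assay: the limit of > 200000 nM in this assay, at which 2 of the 3 values shown sit.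

The compounds shown leave open whether an amine or a carboxylic acid in place of the benzoyl group, or a longer chain in place of benzoylmethyl, would give a number clearly lower in this assay. They also leave open whether a chloro on the aromatic ring of the benzoyl group would change the value of compound 3 at all.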